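Carboxy in place of hydroxy: expected read-out for compound 4

The source may hold more compounds than are shown below. What is called first, only, known or untested is meant among the compounds shown, and "the series" means these compounds.

Measured so far:
compound 1 `CCc1ccc2nc(C(=O)Nc3c(F)cc(-c4cccc(F)c4)cc3F)c(C)c(O)c2c1`: -0.12%
compound 2 `Cc1c(C(=O)Nc2c(F)cc(-c3cccc(F)c3)cc2F)nc2ccc(F)cc2c1O`: -0.13%
compound 3 `Cc1c(C(=O)Nc2c(F)cc(-c3cccc(F)c3)cc2F)nc2ccc(C(F)(F)F)cc2c1O`: 1.28%

In a functional assay on A-375 cells (Homo sapiens) for antiproliferative activity, read by MTT assay, with a stated time of 24 h, tested at 0.02 ug/mL (a lower number here means a weaker effect, a higher number a stronger effect of the compound at the concentration tested), compound 1 stands second highest of the three numbers, with compound 2 nearest and compound 3 furthest; all three lie within the scatter of one another. Compound 4 `CCc1ccc2nc(C(=O)Nc3c(F)cc(-c4cccc(F)c4)cc3F)c(C)c(C(=O)O)c2c1` differs from compound 1 by carboxy in place of hydroxy on an aromatic carbon. Going by the values given here, none of the measured steps touches this change: a number 0 percentage points lower from compound 1 to compound 2 (within the scatter), a number 1.4 percentage points higher from compound 1 to compound 3 (within the scatter) and a number 1.4 percentage points higher from compound 2 to compound 3 (within the scatter) each swap a different group on the shared core, and each stays within the scatter. No measured change in the series has moved the read-out beyond the scatter, so for compound 4 the expected step is a number 0.6 percentage points higher from compound 1 to compound 4 (within the scatter), in no direction beyond the scatter. Compound 4 is therefore estimated at 0.5%, within -9% to 10%.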

Compound 4, a percentage reported as inhibition, at one concentration (the size of the read-out at that concentration, not a potency): -0.12%
Compound 4: middle estimate off by 0.6 percentage points, on the high side; measured number inside the range.
By their numbers in this assay, from the lowest: compounds 2, 1, 4 and 3 (each within the scatter of the next).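

Read in this assay, carboxy in place of hydroxy on the aromatic carbon opposite the ring nitrogen gives no change at the digits printed from compound 1 to compound 4 (within the scatter) and is the first change shown at this position. Going from 1 heavy atom to 3 heavy atoms here leaves the read-out within the scatter, as the changes at the ethyl-bearing carbon did. No measured property bears on this result.

Every compound shown lies within the scatter of the others, so no step yet marks out a group that moves the read-out. Whether an amine or a longer chain at this position would move it remains open, as does the behaviour of these compounds at a higher concentration.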